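The source may report more compounds than this note shows. Statements on the series, on what has been measured and on what is new or still open speak of the compounds shown alone.

Among the measured compounds shown here, compound 2 `O=C(/C=C/c1cccc(NC(=O)c2ccccc2Br)c1)c1nc2ccccc2[nH]1` gives 4520 nM in a functional assay on MCF7 cells (Homo sapiens) for antiproliferative activity, read by MTT assay, with a stated time of 48 h (on this read-out higher numbers stand for weaker inhibition and lower numbers for stronger inhibition), the lower of the two numbers measured so far; compound 1 `O=C(Nc1cccc(/C=C/C(=O)c2nc3ccccc3[nH]2)c1)c1cccc(Cl)c1` gives 7840 nM in this assay. The step from compound 1 to compound 2 exchanged one ring on the carbonyl carbon for another and read a 1.7-fold lower number from compound 1 to compound 2 (0.24 log units; within the scatter). Compound 3 `Cc1cccc(C(=O)Nc2cccc(/C=C/C(=O)c3nc4ccccc4[nH]3)c2)c1` carries the change (3-methylphenyl in place of 2-bromophenyl on a carbonyl carbon). For the measured compounds named here, the only step that bears on this, the step from compound 1 to compound 2, lay within the scatter, so the step from compound 2 to compound 3 is likewise expected to stay within the scatter, estimated as a 1.2-fold higher number from compound 2 to compound 3 (0.09 log units; within the scatter). Compound 3 is therefore expected to give about 5500 nM, between 2000 nM and 15000 nM.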

Compound 3, half-maximal inhibitory concentration: 5590 nM
Compound 3: middle estimate off by 1.0-fold (0.01 log units), on the low side, within the range that was stated.
By their numbers in this assay, from the lowest: compounds 2, 3 and 1 (each within the scatter of the next).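

In this assay the exchange of rings reads a 1.2-fold higher number from compound 2 to compound 3 (0.09 log units; within the scatter) and the swap on the aromatic carbon, methyl in place of chloro, reads a 1.4-fold lower number from compound 1 to compound 3 (0.15 log units; within the scatter). The carbonyl carbon has now carried 3-chlorophenyl, 2-bromophenyl and 3-methylphenyl with every step within the scatter, and a halogen on the ring is not needed to stay in this range. Nothing available accounts for this sameness. On these data alone, whether an amine or a carboxylic acid on this ring would keep the number in the same range remains open, as does the effect of a longer chain there.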